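Hydrazide series: a repeated aryl swap across two cores

A few compounds are considered here, and "the series" means these few. Any claim that something is new, unique, unknown or untested is made for them only; others in the source may bear on it.

Three compounds are measured in a functional assay on MDA-MB-231 cells (Homo sapiens) for antiproliferative activity, read by MTT assay, with a stated time of 24 h; on this read-out lower numbers stand for stronger inhibition and higher numbers for weaker inhibition. Compound 1 `CCCCOc1ccc(C(=O)NNC(=O)c2cccc(NS(=O)(=O)c3cnc(O)nc3O)c2)cc1` gives 17000 nM. Compound 2 `Cc1ccccc1C(=O)NNC(=O)c1cccc(NS(=O)(=O)c2cnc(O)nc2O)c1` gives 18100 nM. Compound 3 `CCCCOc1ccc(C(=O)NNC(=O)c2ccccc2NS(=O)(=O)c2cnc(O)nc2O)cc1` gives 6830 nM, the lowest of the three numbers; the gaps to compound 1 and compound 2 are both beyond the scatter. Compound 1 and compound 3 are built from the same atoms joined differently; the difference between the two cores is not broken down here.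

Going by the values given here, the one change that is measured is 2-methylphenyl in place of 4-butoxyphenyl on a carbonyl carbon, which made the step of a 1.1-fold higher number from compound 1 to compound 2 (0.03 log units; within the scatter). Compound 4 `Cc1ccccc1C(=O)NNC(=O)c1ccccc1NS(=O)(=O)c1cnc(O)nc1O` is not yet measured; it differs from compound 3 by 2-methylphenyl in place of 4-butoxyphenyl on a carbonyl carbon, the same change, at the same place.

Since the change made only a 1.1-fold higher number from compound 1 to compound 2 (0.03 log units; within the scatter), a similarly small step is expected here, and compound 4 is therefore expected to stay close to compound 3 at 6830 nM. The estimated step from compound 3 to compound 4 is a 1.1-fold higher number from compound 3 to compound 4 (0.04 log units; within the scatter). For compound 4 in this assay the estimate is 7500 nM, with an expected range from 3500 nM to 16000 nM; this rests on a single measured instance of the change, so the range is kept wide.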

Compound 4, half-maximal inhibitory concentration: 5570 nM
For compound 4 the middle estimate is 1.3-fold (0.13 log units) above the measured one, and the stated range covers the measured number.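

In this assay, 2-methylphenyl in place of 4-butoxyphenyl on a carbonyl carbon again gives a step within the scatter, a 1.2-fold lower number from compound 3 to compound 4 (0.09 log units; within the scatter). Set side by side, the two instances of this change agree: the same change on two cores in this assay, a 1.1-fold higher number (0.03 log units; within the scatter) from compound 1 to compound 2 and a 1.2-fold lower number (0.09 log units; within the scatter) from compound 3 to compound 4, 1.3-fold (0.12 log units) apart, within the scatter of two such steps

This shows that, for these two cores and this one pair of groups, the change carries from one core to the other and leaves the number within the scatter each time; it does not show that the same would hold on any further core or for any other pair of groups, and it gives no reason why the steps are so small.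

The compounds shown place only two groups at this carbonyl, both six-membered aromatic rings of carbon only, so it remains open whether a pyridine ring, a carboxylic acid on the ring or an aminoalkyl chain would also leave the number in place. Also open is whether a longer chain than butoxy would behave like the two groups shown on either core.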